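Shifting the trifluoromethyl group on the pendant phenyl ring

The compounds below may be only part of what the source reports. "The series", "measured", "known", "first", "only" and "open" are said of these compounds alone.

Three compounds of the series have been run in a functional assay on HCT-15 cells (Homo sapiens) for inhibition; on this read-out higher numbers stand for weaker inhibition and lower numbers for stronger inhibition. Compound 1 `Oc1cccc(-c2cc(-c3cccc(F)c3)cc(-c3ccccc3O)n2)c1` gives only a limit there, > 50000 nM. Compound 2 `Oc1ccccc1-c1cc(-c2ccc(C(F)(F)F)cc2)cc(-c2ccccc2O)n1` likewise gives only a limit, > 50000 nM. Within the data shown here, compound 3 `Oc1cccc(-c2cc(-c3cccc(C(F)(F)F)c3)cc(-c3ccccc3O)n2)c1` gives 6460 nM, the single number in this assay so far. Compound 1 and compound 2 give no number, so compound 3 cannot be ranked against them beyond the statement that it gives a number where they do not. Among the measured compounds shown here, the one measured step, an at least 7.7-fold lower number from compound 1 to compound 3 (0.88 log units; beyond the scatter), is read against (the limit of > 50000 nM in this assay, at which 2 of the 3 values shown sit).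

Compound 4 `Oc1cccc(-c2cc(-c3ccc(C(F)(F)F)cc3)cc(-c3ccccc3O)n2)c1` carries the change (4-(trifluoromethyl)phenyl in place of 3-(trifluoromethyl)phenyl on an aromatic carbon). For the measured compounds named here, no measured step moves a trifluoromethyl group from one place on this phenyl ring to another, so the step from compound 1 to compound 3 bears on it only indirectly. Compound 2, which also carries a 4-(trifluoromethyl)phenyl group, sits at the limit of this assay, whereas compound 3 gives a number.

Compound 4 is therefore expected to give 20000 nM, in the range 6000 nM to 60000 nM, with a fair chance that only a limit is recorded. The expected step of a 3.1-fold higher number from compound 3 to compound 4 (0.49 log units; beyond the scatter) is a weakening that may reach beyond the scatter.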

Compound 4, half-maximal inhibitory concentration: > 50000 nM
Compound 4 ended at the assay's limit; the forecaster's own chance of this, stated with the estimate: 40%; at least 2.5-fold (0.39 log units) between middle value and limit.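

In this assay compound 4 gives > 50000 nM and that is a limit, not a number. Compound 3 and compound 4 have the same atoms, so the shift from 3-(trifluoromethyl)phenyl to 4-(trifluoromethyl)phenyl on the carbon opposite the ring nitrogen is enough on its own for an at least 7.7-fold higher number from compound 3 to compound 4 (0.88 log units; beyond the scatter) and the presence of a trifluoromethyl group on this ring does not by itself give a number. The steps to compound 4 from compound 1 and from compound 2 cannot be read, and the size of the shift stays open at its upper end: the limit of > 50000 nM in this assay, at which 3 of the 4 values shown sit.

Still open, from the compounds shown here alone, is whether another group on the phenyl ring of compound 3, such as a nitrile, a methoxy group or an amine, would also give a number in this assay. Also open, going by these compounds, is whether the number of compound 3 depends on its pairing of 3-(trifluoromethyl)phenyl with the 3-hydroxyphenyl group, the only setting in which a number appears so far.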